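A few compounds are considered here, and "the series" means these few. Any claim that something is new, unique, unknown or untested is made for them only; others in the source may bear on it.

Within the data shown here, compound 2, `CN(CC[C@@H](Oc1ccc(-c2ccccc2)cc1)c1ccccc1)CC(=O)O`, gives 151 nM in an assay on CHO cells for inhibition of sodium- and chloride-dependent glycine transporter 1 (Homo sapiens) (on this read-out higher numbers stand for weaker inhibition and lower numbers for stronger inhibition), the lowest of the two numbers measured so far. Compound 1, `CCN(CCC(Oc1ccc(C(F)(F)F)cc1)c1ccccc1)CC(=O)O`, gives 5010 nM in this assay, a much higher number that lies well beyond the scatter. Compound 3, `CN(CC[C@H](Oc1ccc(-c2ccccc2)cc1)c1ccccc1)CC(=O)O`, differs from compound 2 only in this respect: the two compounds have the same atoms and bonds and differ only in configuration as drawn: 1 of 1 stereo elements differ; a stereocentre at a saturated chain carbon is drawn R in compound 2 and S in compound 3. Changing the configuration of the single stereocentre often weakens inhibition considerably, so the number is expected to rise, by a step of a 9.9-fold higher number from compound 2 to compound 3 (1.00 log units; beyond the scatter) that goes beyond the scatter. Compound 3 is therefore estimated at 1500 nM in this assay, within a range from 300 nM to 8000 nM.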

Compound 3, half-maximal inhibitory concentration: 977 nM
Compound 3: the middle estimate sits 1.5-fold (0.19 log units) above what was measured; the range from low to high includes it.
By their numbers in this assay, from the lowest: compound 2; then compound 3; then compound 1.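

Drawing the stereocentre at the saturated chain carbon S rather than R brings a 6.5-fold higher number from compound 2 to compound 3 (0.81 log units; beyond the scatter) in this assay and so weakens inhibition. Among these compounds, this is the first pair to test this position alone, as compounds 1 and 2 differ in more than one place. The loss can be assigned to configuration alone, because no atom or bond changes: the fact that compounds 2 and 3 differ only in the configuration as drawn

Going by these compounds, whether R stays favoured with another group on the nitrogen, such as a propyl chain, remains open. Compound 1 has no configuration drawn, so it cannot settle this.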